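The source may hold more compounds than are shown below. What is called first, only, known or untested is meant among the compounds shown, and "the series" means these compounds.

Measured in an assay on CHO cells for binding affinity to metabotropic glutamate receptor 2 (Rattus norvegicus); on this read-out lower numbers stand for stronger inhibition and higher numbers for weaker inhibition:
compound 1 `CO[C@@H]1C[C@@H]2[C@H]([C@]1(N)C(=O)O)[C@@]2(F)C(=O)O`: 39.2 nM
compound 2 `Nc1cccc(CO[C@@H]2C[C@@H]3[C@H]([C@]2(N)C(=O)O)[C@@]3(F)C(=O)O)c1`: 15.4 nM
compound 3 `N[C@]1(C(=O)O)[C@H]2[C@@H](C[C@H]1OCc1cc(Cl)ccc1Cl)[C@]2(F)C(=O)O`: 11.8 nM

Compound 3 shows the lowest number of the three in this assay; compound 2 lies within the scatter of it, while compound 1 is further off. Compound 4 `N[C@]1(C(=O)O)[C@H]2[C@@H](C[C@H]1OCc1cccs1)[C@]2(F)C(=O)O` differs from compound 3 by thiophen-2-yl in place of 2,5-dichlorophenyl on a saturated chain carbon bound to an oxygen on a saturated carbon. For the measured compounds named here, the steps that bear on this are the two in which a ring replaced hydrogen at this place, a 3.3-fold lower number from compound 1 to compound 3 (0.52 log units; beyond the scatter) and a 2.5-fold lower number from compound 1 to compound 2 (0.41 log units; beyond the scatter), and the exchange of one ring for the other, a 1.3-fold lower number from compound 2 to compound 3 (0.12 log units; within the scatter). So far the presence of a ring at this place mattered, its identity did not. For compound 4 the step from compound 3 is therefore expected to be small, about a 1.7-fold higher number from compound 3 to compound 4 (0.23 log units; within the scatter), not clearly beyond the scatter. Compound 4 is estimated at 20 nM, range 8 nM to 50 nM.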

Compound 4, inhibition constant: 8.79 nM
Estimate against measurement, compound 4: 2.3-fold (0.36 log units) above; measured number inside the range.
By their numbers in this assay, from the lowest: compounds 4, 3 and 2 (each within the scatter of the next); then compound 1.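

In this assay, a five-membered aromatic ring with 1 hetero atom serves this place as well as the two substituted phenyl rings, with a 1.3-fold lower number from compound 3 to compound 4 (0.13 log units; within the scatter) and a 1.8-fold lower number from compound 2 to compound 4 (0.24 log units; within the scatter) both within the scatter. The drop from 8 heavy atoms to 5 in the group therefore brings no measurable loss, and the gain over hydrogen remains, with a 4.5-fold lower number from compound 1 to compound 4 (0.65 log units; beyond the scatter). No evidence on why this holds is available.

Whether the ring must be aromatic remains open, as cyclohexyl is not among the compounds shown. As far as these compounds go, the effect at this place of a longer chain ending in an amine or a carboxylic acid also remains open.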